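A few compounds are considered here, and "the series" means these few. Any claim that something is new, unique, unknown or untested is made for them only; others in the source may bear on it.

In a functional assay on the whole organism (strain Kunming) with Mus musculus as the target, with a stated time of 0.5 h (on this read-out lower numbers stand for an effect already at smaller amounts and higher numbers for an effect only at larger amounts of compound), compound 1 (`COc1cc(OC)c(OC)cc1/C=C/COC(=O)/C=C/c1ccccc1Cl`) gives 58.7 mg/kg, compound 2 (`COc1cc(OC)c(OC)cc1/C=C/COC(=O)/C=C/c1ccc(F)cc1`) gives 34.6 mg/kg and compound 3 (`COc1ccc(/C=C/C(=O)OC/C=C/c2cc(OC)c(OC)cc2OC)cc1`) gives 70.6 mg/kg. The standing of the last of these is set by a 1.2-fold higher number from compound 1 to compound 3 (0.08 log units; within the scatter) and by a 2.0-fold higher number from compound 2 to compound 3 (0.31 log units; beyond the scatter). Compound 4 (`COc1cc(OC)c(OC)cc1/C=C/COC(=O)/C=C/c1ccc(Cl)cc1`) has chloro in place of methoxy on an aromatic carbon, para to a large group: chloro in place of methoxy on an aromatic carbon. The nearest evidence is a 2.0-fold higher number from compound 2 to compound 3 (0.31 log units; beyond the scatter), where methoxy replaces fluoro on an aromatic carbon, so this change runs the opposite way, from methoxy to a halogen. Also relevant is a 1.7-fold lower number from compound 1 to compound 2 (0.23 log units; within the scatter), a step between two halogen-bearing compounds. A small shift to a lower number is therefore expected, probably not clearly beyond the scatter: the expected change is a 1.5-fold lower number from compound 3 to compound 4 (0.19 log units; within the scatter). For compound 4 the estimated value is 46 mg/kg, with an expected range of 26 mg/kg to 80 mg/kg.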

Compound 4, dose for half-maximal effect: 53.4 mg/kg
Compound 4: the middle estimate sits 1.2-fold (0.06 log units) below what was measured; low and high end bracket the measured number.
By their numbers in this assay, from the lowest: compounds 2, 4, 1 and 3 (each within the scatter of the next, the first and the last beyond it).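

In this assay, chloro at this place, para to a large group, stays within the scatter of methoxy (a 1.3-fold lower number from compound 3 to compound 4 (0.12 log units; within the scatter)) and of fluoro (a 1.5-fold higher number from compound 2 to compound 4 (0.19 log units; within the scatter)). Shifting the halogen from 2-chlorophenyl to 4-chlorophenyl also stays within the scatter (a 1.1-fold lower number from compound 1 to compound 4 (0.04 log units; within the scatter)). Going by these compounds alone, compound 4 therefore sits within the scatter of compound 2 and compound 3, the only pair printed beyond it, and no measured evidence bears on these small steps. Still open, on these data alone, is whether an amine or a carboxylic acid at this place would move the number beyond the scatter.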